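Cytotoxicity Limits Across Three Acrylamide Analogues and a Fourth

The compounds below may be only part of what the source reports. "The series", "measured", "known", "first", "only" and "open" are said of these compounds alone.

Compound 3 `Cc1cc(C#N)cc(C)c1Oc1nc(Nc2ccc(C#N)cc2)ncc1/C=C/C(=O)NCC1CCN(S(C)(=O)=O)CC1` carries a (1-(methylsulfonyl)piperidin-4-yl)methyl group on an amide-type nitrogen. In an ADME assay on TZM cells (Homo sapiens) for cytotoxicity, with a stated time of 1 days (on this read-out higher numbers stand for lower toxicity in this test and lower numbers for higher toxicity in this test), compound 3 gives > 171 nM, which is a limit of the assay and not a number. Compound 1 `Cc1cc(C#N)cc(C)c1Oc1nc(Nc2ccc(C#N)cc2)ncc1/C=C/C(=O)NC1CC1` has cyclopropyl in that place, and in this assay compound 1 gives > 221 nM, again only a limit. Compound 2 `COCCNC(=O)/C=C/c1cnc(Nc2ccc(C#N)cc2)nc1Oc1c(C)cc(C#N)cc1C` carries 2-methoxyethyl there; in this assay compound 2 gives > 213 nM, also a limit. The steps a step that the two limits leave unreadable from compound 1 to compound 2, a step that the two limits leave unreadable from compound 1 to compound 3 and a step that the two limits leave unreadable from compound 2 to compound 3 thus have no readable size, as the lines (the limit of > 171 nM in this assay, at which 1 of the 3 values shown sits), the limit of > 213 nM in this assay, at which 1 of the 3 values shown sits, and the limit of > 221 nM in this assay, at which 1 of the 3 values shown sits, show. Compound 4 `Cc1cc(C#N)cc(C)c1Oc1nc(Nc2ccc(C#N)cc2)ncc1/C=C/C(=O)NC1CCN(C(=O)C(F)(F)F)CC1` differs from compound 3 by 1-((trifluoromethyl)carbonyl)piperidin-4-yl in place of (1-(methylsulfonyl)piperidin-4-yl)methyl on an amide-type nitrogen. All three measured steps concern a change at this same nitrogen, yet none can be sized, so no direction is expected in this assay beyond a result that again reaches the limit. Compound 4 is therefore estimated at 220 nM, with a range from 120 nM to 600 nM. The corresponding expected step is a step that the limit leaves unreadable from compound 3 to compound 4.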

Compound 4, half-maximal cytotoxic concentration: > 170 nM
Compound 4: a limit, no number (the forecaster's own chance of this, stated with the estimate: 80%); the middle value lies beyond the limit too.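

In this assay compound 4 gives > 170 nM, which is a limit and not a number, so its steps from compound 1, compound 2 and compound 3 cannot be read. The compounds shown leave open the actual half-maximal cytotoxic concentration of all four compounds.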